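The compounds below may be only part of what the source reports. "The series", "measured", "known", "first", "only" and "open" are said of these compounds alone.

Compound 3 `Cc1ccc(NC(=O)NC(=O)c2ccc(OCc3ccc(C(F)(F)F)cc3)cc2)cc1-c1nc2ccccc2[nH]1` gives 7830 nM in a functional assay on HT-29 cells (Homo sapiens) for inhibition, read by MTT assay, with a stated time of 48 h (a higher number here means a weaker inhibitor, a lower number a stronger inhibitor), the second highest of the three numbers; compound 2 `O=C(NC(=S)Nc1ccc(Cl)c(-c2nc3ccccc3[nH]2)c1)c1ccc(OCc2ccc(Cl)c(Cl)c2)cc1` gives 4930 nM and compound 1 `O=C(NC(=S)Nc1ccc(Cl)c(-c2nc3ccccc3[nH]2)c1)c1ccc(OCc2ccc(C(F)(F)F)cc2)cc1` gives 12900 nM, and both of these lie within the scatter of compound 3. Compound 4 `Cc1ccc(COc2ccc(C(=O)NC(=O)Nc3ccc(C)c(-c4nc5ccccc5[nH]4)c3)cc2)cc1` differs from compound 3 by methyl in place of trifluoromethyl on an aromatic carbon. Among the compounds with values here, the one measured step at this place is a 2.6-fold lower number from compound 1 to compound 2 (0.42 log units; beyond the scatter), which exchanges a different group on a saturated chain carbon bound to an oxygen on an aromatic ring, so it bears on the present change only loosely. A step of at most modest size is therefore expected, with its direction open. The estimate for compound 4 is 7000 nM with a range of 2500 nM to 20000 nM, an expected step of a 1.1-fold lower number from compound 3 to compound 4 (0.05 log units; within the scatter), likely within the scatter.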

Compound 4, half-maximal inhibitory concentration: 5110 nM
For compound 4 the middle estimate is 1.4-fold (0.14 log units) above the measured one; measured number inside the range.
By their numbers in this assay, from the lowest: compounds 2, 4, 3 and 1 (each within the scatter of the next, the first and the last beyond it).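

In this assay, within the data shown here, methyl in place of trifluoromethyl on the aromatic carbon para to a large group gives a 1.5-fold lower number from compound 3 to compound 4 (0.19 log units; within the scatter) and is the first step read at this carbon itself. In this pair, going from 4 heavy atoms to 1 at this place leaves the two numbers within the scatter of each other. No measured evidence here explains this result. On these data alone, whether an amine or a carboxylic acid on this carbon would move the number beyond the scatter stays open. So does whether methyl in place of trifluoromethyl gives a similar step on the core of compound 1.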